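Methyl for isopropyl on the ring amide nitrogen

This account rests on a few compounds, and the source may have more. Where it says the series, first, only, none or still open, it means among the compounds named here.

Measured compounds:
compound 1 `COC(=O)C1=CN(C)C(=O)[C@@H]2C(CN3CCN(Cc4ccc(C(F)(F)F)cc4)CC3)=CC[C@H]12`: 72.2%
compound 2 `COC(=O)C1=CN(C(C)C)C(=O)[C@@H]2C(CN3CCN(Cc4ccc([N+](=O)[O-])cc4)CC3)=CC[C@H]12`: 74.3%
compound 3 `COC(=O)C1=CN(C(C)C)C(=O)[C@@H]2C(CN3CCN(Cc4cccc(C(F)(F)F)c4)CC3)=CC[C@H]12`: 71.6%

In a functional assay on Cortical neurone cells (Rattus norvegicus, strain Sprague-Dawley), read by MTT assay, with stated times of 24 h and 2 h, tested at 1 uM (on this read-out higher numbers stand for a stronger effect at the one concentration tested and lower numbers for a weaker effect), compound 3 gives the lowest of the three numbers, yet both other compounds sit within the scatter of it: compound 1 gives 72.2% and compound 2 gives 74.3%. Going by the values given here, the one step measured so far, a number 2.7 percentage points lower from compound 2 to compound 3 (within the scatter), exchanged the aryl group on the chain carbon and stayed within the scatter.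

Compound 4 `COC(=O)C1=CN(C)C(=O)[C@@H]2C(CN3CCN(Cc4cccc(C(F)(F)F)c4)CC3)=CC[C@H]12` is the next compound. It differs from compound 3 in one place: methyl in place of isopropyl on an amide-type nitrogen in a ring. Among the compounds with values here, no measured step touches this amide-type nitrogen, so nothing measured bears directly on it. Within the data shown here, compound 1 carries the same methyl and gives 72.2%, and all three numbers so far lie close together. The step of a number 0.4 percentage points higher from compound 3 to compound 4 (within the scatter) is therefore expected to stay within the scatter, in no clear direction. Compound 4 is estimated at 72%, between 62% and 82%.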

Compound 4, a percentage reported as activity, at one concentration (the size of the read-out at that concentration, not a potency): 72.5%
The estimate for compound 4 lay 0.5 percentage points below the measured number; the measured number falls inside the stated range.
By their numbers in this assay, from the lowest: compounds 3, 1, 4 and 2 (each within the scatter of the next).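

In this assay, going by these compounds alone, the exchange on the amide-type nitrogen in a ring gives a number 0.9 percentage points higher from compound 3 to compound 4 (within the scatter) and is the first direct test of that nitrogen: going from isopropyl with its 3 heavy atoms to methyl with 1 heavy atom leaves the result within the scatter. With methyl on this nitrogen, 3-(trifluoromethyl)phenyl in place of 4-(trifluoromethyl)phenyl gives a number 0.3 percentage points higher from compound 1 to compound 4 (within the scatter) and also stays within the scatter, so neither change separates these compounds at the one concentration tested. No supporting information is available to explain why the numbers stay so close. Going by these compounds, both groups tested on this nitrogen are small alkyl groups, so the effect of a benzyl group or of the amide hydrogen there remains open. On these data alone, whether a larger group can move the result beyond the scatter also remains open.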